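A few compounds are considered here, and "the series" means these few. Any claim that something is new, unique, unknown or untested is made for them only; others in the source may bear on it.

Compound 3 `NC(=O)[C@@H](CCC(F)(F)F)N(CC1CCOCC1)S(=O)(=O)c1ccc(Cl)cc1` is measured in an in vitro ADME assay on microsomes from liver (Homo sapiens) for metabolic stability, read by HPLC (a higher number here means faster removal of the compound, a lower number slower removal), at 114 mL/min/kg, the lowest of the two numbers shown, though the gap to compound 2 `NC(=O)[C@@H](CCC(F)(F)F)N(C[C@H]1CCCOC1)S(=O)(=O)c1ccc(Cl)cc1`, which gives 156 mL/min/kg, is only a 1.4-fold lower number from compound 2 to compound 3 (0.14 log units; within the scatter). Compound 1 `CC1(C)CO[C@@H]1CN([C@H](CCC(F)(F)F)C(N)=O)S(=O)(=O)c1ccc(Cl)cc1` reaches just a limit of this assay, > 293 mL/min/kg. The remaining known steps are an at least 1.8-fold lower number from compound 1 to compound 2 (0.27 log units; that floor lies within the scatter) and an at least 2.5-fold lower number from compound 1 to compound 3 (0.40 log units; beyond the scatter). Compound 4 `NC(=O)[C@@H](CCC(F)(F)F)N(C[C@H]1CCOC1)S(=O)(=O)c1ccc(Cl)cc1` carries oxolan-3-yl in place of oxan-4-yl on a saturated chain carbon bound to a sulfonamide nitrogen. Within the data shown here, no measured step exchanges a six-membered for a five-membered ring; the oxetane-to-oxane steps were the larger ones, while moving the oxygen within the oxane stayed within the scatter. For compound 4 a step no larger than the scatter is therefore expected, a 1.1-fold higher number from compound 3 to compound 4 (0.04 log units; within the scatter). Compound 4 is estimated at 125 mL/min/kg, between 60 mL/min/kg and 260 mL/min/kg.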

Compound 4, clearance: 83.4 mL/min/kg
For compound 4 the middle estimate is 1.5-fold (0.18 log units) above the measured one; the measured number falls inside the stated range.
By their numbers in this assay, from the lowest: compounds 4, 3 and 2 (each within the scatter of the next). At a limit, above all of these: compound 1.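

Oxolan-3-yl brings the first five-membered ring to this place on a saturated chain carbon bound to a sulfonamide nitrogen, and in this assay it does not separate from either oxane, with a 1.4-fold lower number from compound 3 to compound 4 (0.14 log units; within the scatter) and a 1.9-fold lower number from compound 2 to compound 4 (0.27 log units; within the scatter). The two oxanes and the oxolane thus form one group within the scatter. The step from the 3,3-dimethyloxetan-2-yl, an at least 3.5-fold lower number from compound 1 to compound 4 (0.54 log units; beyond the scatter), is a floor beyond the scatter, as its starting value is a limit of the assay: the limit of > 293 mL/min/kg in this assay, at which 1 of the 4 values shown sits.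

The compounds shown leave open how a ring without oxygen, such as cyclohexyl, or a ring amine, such as piperidin-4-yl, would read at this place.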